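The compounds below may be only part of what the source reports. "The series", "measured", "known", "first", "only" and "open" are said of these compounds alone.

Of the compounds shown here, three sharing one core have been measured in a functional assay on GBM2 cells (Homo sapiens) for antiproliferative activity, read by WST assay, with a stated time of 72 h; a higher number here means a weaker inhibitor, a lower number a stronger inhibitor. Compound 1 `O=C(Nc1cccc(Cl)c1)Nc1cc2ncncc2cc1OCc1ccccc1Cl` gives 2100 nM, compound 2 `O=C(Nc1ccc(C(F)(F)F)cc1)Nc1cc2ncncc2cc1OCc1cccc(F)c1` gives 3200 nM, and compound 3 `O=C(Nc1cccc(Cl)c1)Nc1cc2ncncc2cc1OCc1cccc(Cl)c1` gives 3500 nM. Compound 3 lies within the usual scatter of both others, so these numbers support no ranking among the three.

The unmeasured compound 4 `O=C(Nc1ccc(C(F)(F)F)cc1)Nc1cc2ncncc2cc1OCc1cccc(Cl)c1` differs from compound 3 in one place: 4-(trifluoromethyl)phenyl in place of 3-chlorophenyl on an amide-type nitrogen. In words, 4-(trifluoromethyl)phenyl replaces 3-chlorophenyl on an amide-type nitrogen. Going by the values given here, no measured step makes this exact swap. Among the compounds with values here, the only single-place step available is a 1.7-fold higher number from compound 1 to compound 3 (0.22 log units; within the scatter), which stays within the scatter and concerns a different part of the molecule, where 3-chlorophenyl replaces 2-chlorophenyl on a saturated chain carbon bound to an oxygen on an aromatic ring. It therefore offers only indirect guidance. Compound 2 already carries 4-(trifluoromethyl)phenyl on an amide-type nitrogen, although it also differs elsewhere, and its 3200 nM lies within the scatter of the value for compound 3.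

On this evidence, no step beyond the scatter is expected in this assay, in either direction. The expected change is a 1.1-fold lower number from compound 3 to compound 4 (0.03 log units; within the scatter), an estimate that stays within the scatter. For compound 4, the estimated value is 3300 nM, with an expected range from 1500 nM to 7000 nM.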

Compound 4, half-maximal inhibitory concentration: 4700 nM
Compound 4: the middle estimate sits 1.4-fold (0.15 log units) below what was measured, and the stated range covers the measured number.
By their numbers in this assay, from the lowest: compounds 1, 2, 3 and 4 (each within the scatter of the next, the first and the last beyond it).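

In this assay, going by these compounds alone, the step on the amide-type nitrogen, where 4-(trifluoromethyl)phenyl replaces 3-chlorophenyl, is a 1.3-fold higher number from compound 3 to compound 4 (0.13 log units; within the scatter) and gives the first direct reading of a change at this place. Despite the larger group that enters, with 10 heavy atoms against 7, the step stays within the usual scatter, so this pair shows no measurable difference between these two groups on that nitrogen, and a second pair adds that chloro in place of fluoro on an aromatic carbon is a 1.5-fold higher number from compound 2 to compound 4 (0.17 log units; within the scatter) and also stays within the scatter. Neither step can be explained from the data shown, as no separate measurement bears on the cause of either result.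

Going by these compounds, both groups on the amide-type nitrogen are aromatic rings of carbon only with no hydrogen-bond donors or acceptors, so it remains open how a ring carrying an amine or a carboxylic acid would read at the same place. Also open, on these data alone, is whether a longer chain in place of the aromatic ring would give a step beyond the scatter.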